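The source may report more compounds than this note shows. Statements on the series, on what has been measured and on what is new or still open speak of the compounds shown alone.

Compound 3 `COc1cc(-c2cc(C(=O)O)c3ccccc3n2)ccc1OCC(=O)Nc1cccc(C(F)(F)F)c1` stands lowest of the three measured compounds in a physicochemical assay for lipophilicity, using the shake flask method, in phosphate buffer, measured as octanol-water partition, at pH 7.4 (on this read-out higher numbers stand for higher lipophilicity and lower numbers for lower lipophilicity), at 1.3. Compound 1 `COc1cc(-c2cc(C(=O)O)c3ccccc3n2)ccc1OCC(=O)Nc1cccc(C)c1` gives 1.5 and compound 2 `COc1cc(-c2cc(C(=O)O)c3ccccc3n2)ccc1OCC(=O)Nc1cccc(Cl)c1` gives 2.3; the measured steps read a number 0.80 log units higher from compound 1 to compound 2 (beyond the scatter), a number 0.20 log units lower from compound 1 to compound 3 (within the scatter) and a number 1.00 log units lower from compound 2 to compound 3 (beyond the scatter). Compound 4 `CCCCCCNC(=O)COc1ccc(-c2cc(C(=O)O)c3ccccc3n2)cc1OC` carries hexyl in place of 3-(trifluoromethyl)phenyl on an amide-type nitrogen. For the measured compounds named here, none of the measured steps bears on a change of this kind: each of them exchanges one substituent on an aromatic carbon for another, whereas here the whole aromatic ring gives way to a chain. No step size can be carried over from the series, so the expectation for compound 4 rests on the spread of the three numbers already in hand. For compound 4 a value of 1.6 is estimated, within 0.8 to 2.4, which means an expected step of a number 0.30 log units higher from compound 3 to compound 4 (within the scatter).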

Compound 4, distribution coefficient: 1
The estimate for compound 4 lay 0.60 log units above the measured number, and the stated range covers the measured number.
By their numbers in this assay, from the lowest: compounds 4, 3 and 1 (each within the scatter of the next, the first and the last beyond it); then compound 2.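

Hexyl in place of an aryl group on the amide-type nitrogen gives the first change away from the substituents on the aromatic ring: in this assay the step reads a number 0.30 log units lower from compound 3 to compound 4 (within the scatter) and so an aromatic ring at this place is not required for a number in the range of compound 3. The same exchange reads a number 0.50 log units lower from compound 1 to compound 4 (beyond the scatter) and also a number 1.30 log units lower from compound 2 to compound 4 (beyond the scatter) so its size depends on which aryl group leaves. Nothing available explains these differences.

As far as these compounds go, whether a shorter or longer chain on this nitrogen would stay near compound 4 remains open. So does the effect of a chain ending in an amine or a carboxylic acid.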